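Inverting one ring stereocentre: compound 3 to compound 4

The source may report more compounds than this note shows. Statements on the series, on what has been measured and on what is new or still open speak of the compounds shown alone.

Measured in a functional assay on HeLa cells (Homo sapiens) for cytotoxicity, read by MTT assay, with a stated time of 48 h; a higher number here means a weaker inhibitor, a lower number a stronger inhibitor:
- compound 1 (`CCOC(=O)C1(C(=O)Nc2ccccc2Cl)CC1c1cc(OC)c(OC)c(OC)c1`): (22100 nM; 76400 nM (2 entries))
- compound 2 (`CCOC(=O)[C@@]1(C(=O)NCc2ccc(C)cc2)C[C@H]1c1cc(OC)c(OC)c(OC)c1`): (19700 nM)
- compound 3 (`CCOC(=O)[C@]1(C(=O)Nc2ccccc2Cl)C[C@H]1c1cc(OC)c(OC)c(OC)c1`): (42400 nM)

Compound 3 holds the highest of the two single numbers, and compound 2 sits lower, a gap beyond the usual scatter. Compound 1 gives no single number (the several entries of compound 1 in this assay, 22100 nM; 76400 nM (2 entries)). Compound 4 (`CCOC(=O)[C@@]1(C(=O)Nc2ccccc2Cl)C[C@H]1c1cc(OC)c(OC)c(OC)c1`) remains unmeasured and departs from compound 3 in one place (the two compounds have the same atoms and bonds and differ only in configuration as drawn: 1 of 2 stereo elements differ; a stereocentre at a saturated ring carbon is drawn R in compound 3 and S in compound 4): a stereocentre at a saturated ring carbon is drawn R in compound 3 and S in compound 4. For the measured compounds named here, no measured step isolates such a change. The entries of compound 1 (22100 nM; 76400 nM (2 entries)), which lacks a defined configuration there (the fact that one of compounds 1 and 3 is drawn with a defined configuration and the other without, at the place where they differ), fall on either side of compound 3 (42400 nM). In this assay a step within the scatter is therefore expected, without a firm direction. The estimated step is small (a 1.2-fold lower number from compound 3 to compound 4 (0.08 log units; within the scatter)). The expected value for compound 4 is 35000 nM (estimated range 14000 nM to 80000 nM).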

Compound 4, half-maximal inhibitory concentration: 14400 nM
Beside the measured number, compound 4's estimate is 2.4-fold (0.39 log units) above it, within the range that was stated.
By their numbers in this assay, from the lowest: compounds 4 and 2 (each within the scatter of the next); then compound 3.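

In this assay, for the compounds shown here, this pair gives the first measured step at this ring stereocentre, a 2.9-fold lower number from compound 3 to compound 4 (0.47 log units; beyond the scatter), with the lower number on the centre drawn S. That step can be read on configuration alone: the fact that compounds 3 and 4 differ only in the configuration as drawn. With this configuration, 2-chlorophenyl in place of 4-methylbenzyl on an amide-type nitrogen gives a 1.4-fold lower number from compound 2 to compound 4 (0.14 log units; within the scatter), so the two groups are not told apart here.

From the compounds shown here alone, whether inverting this centre gives a similar step with 4-methylbenzyl on that nitrogen stays open, as does the effect of inverting the other stereocentre. Going by these compounds, how a carboxylic acid in place of the ethyl ester would read in this assay is also open.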